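A few compounds are considered here, and "the series" means these few. Any claim that something is new, unique, unknown or untested is made for them only; others in the source may bear on it.

Measured so far in a physicochemical assay for lipophilicity, read by HPLC, at pH 7.5; on this read-out higher numbers stand for higher lipophilicity and lower numbers for lower lipophilicity:

- compound 1 `N#Cc1c(-c2ccc(Br)cc2)nc2cnccc2c1NCC(N)=O` gives 1.9
- compound 2 `CC[C@@H](Nc1c(C#N)c(-c2ccc(Br)cc2)nc2cnccc12)C(=O)O` gives 1.6
- compound 3 `CN(CC(N)=O)c1c(C#N)c(-c2ccc(Br)cc2)nc2cnccc12` gives 2.1

Two steps show where compound 2 stands. One stays inside the scatter (a number 0.30 log units lower from compound 1 to compound 2 (within the scatter)) and the other goes past it (a number 0.50 log units higher from compound 2 to compound 3 (beyond the scatter)) on these numbers.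

Compound 4 `CC[C@@H](Nc1c(C#N)c(-c2ccc(-c3cccc(Cl)c3F)cc2)nc2cnccc12)C(=O)O` has not been measured yet. It carries 3-chloro-2-fluorophenyl in place of bromo on an aromatic carbon of compound 2 (3-chloro-2-fluorophenyl in place of bromo on an aromatic carbon) and is otherwise the same.

Going by the values given here, all the measured steps, including the remaining one (a number 0.20 log units higher from compound 1 to compound 3 (within the scatter)) , alter the group on the amino nitrogen and leave bromo untouched. None of them measures this swap directly, and the largest is only modest. With a whole aromatic ring entering, a rise larger than any of them is expected, although this is a judgement without a measured precedent.

The expected move is a number 1.30 log units higher from compound 2 to compound 4 (beyond the scatter) as an estimate. For compound 4 the estimated value is 2.9, with an expected range from 2.3 to 3.6 at its two ends.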

Compound 4, distribution coefficient: 2.2
Compound 4: the middle estimate sits 0.70 log units above what was measured; the measured number lies below the stated range.
By their numbers in this assay, from the lowest: compounds 2, 1, 3 and 4 (each within the scatter of the next, the first and the last beyond it).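

Until now every measured change sat on the amino nitrogen. Going by these compounds alone, this is the first step at the aromatic carbon that held bromo, and in this assay putting 3-chloro-2-fluorophenyl there gives a number 0.60 log units higher from compound 2 to compound 4 (beyond the scatter). So this position does move the read-out, yet a group of 8 heavy atoms with a whole aromatic ring, replacing a single bromine, produces a step of only modest size. No measured information on hand explains why the step has this size.

On these data alone, this reading rests on one pair carrying the 1-carboxypropyl group, so whether the same swap gives a similar step with the carbamoylmethyl group of compound 1 stays open. The compounds shown also cannot separate the shares of the ring, the chlorine and the fluorine, which a plain phenyl or a phenyl carrying an amine at this position could begin to address.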